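Bromo for Chloro on the Benzyl Ring

This account rests on a few compounds, and the source may have more. Where it says the series, first, only, none or still open, it means among the compounds named here.

Compound 1 `Cc1cccc(Cn2cc(COc3ccc4c(=O)ccoc4c3)nn2)c1` gives 16000 nM in a functional assay on MDA-MB-231 cells (Homo sapiens) for cytotoxicity, read by MTT assay, with a stated time of 48 h; on this read-out higher numbers stand for weaker inhibition and lower numbers for stronger inhibition. Compound 2 `O=c1ccoc2cc(OCc3cn(Cc4ccc(Cl)cc4)nn3)ccc12` reaches only a limit of this assay, > 100000 nM. Compound 3 `O=c1ccoc2cc(OCc3cn(Cc4ccccc4Cl)nn3)ccc12` gives 15100 nM.

Compound 3 and compound 1 sit together within the scatter, as a 1.1-fold lower number from compound 1 to compound 3 (0.03 log units; within the scatter) shows, while compound 2 sits at a limit (the limit of > 100000 nM in this assay, at which 1 of the 3 values shown sits), so that an at least 6.6-fold lower number from compound 2 to compound 3 (0.82 log units; beyond the scatter). Compound 4 `O=c1ccoc2cc(OCc3cn(Cc4ccccc4Br)nn3)ccc12` differs from compound 3 by bromo in place of chloro on an aromatic carbon. Going by the values given here, no measured step swaps one halogen for another at the same place; the measured steps exchange the whole aryl group. Compound 4 is therefore expected to stay close to compound 3, with a 1.1-fold lower number from compound 3 to compound 4 (0.03 log units; within the scatter). The estimate for compound 4 is 14000 nM, between 5000 nM and 40000 nM.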

Compound 4, half-maximal inhibitory concentration: > 100000 nM
Compound 4: a limit, no number (the forecaster's own chance of this, stated with the estimate: 10%); middle value at least 7.1-fold (0.85 log units) away from the limit.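

In this assay, the halogen itself matters at this place on the benzyl ring: exchanging only chloro for bromo, a change of one heavy atom, gives an at least 6.6-fold higher number from compound 3 to compound 4 (0.82 log units; beyond the scatter). The 2-bromobenzyl compound also separates from the 3-methylbenzyl compound, with an at least 6.2-fold higher number from compound 1 to compound 4 (0.79 log units; beyond the scatter). Compound 4 sits at a limit of this assay, as does compound 2, so the step between those two cannot be read: the limit of > 100000 nM in this assay, at which 2 of the 4 values shown sit.

As far as these compounds go, it remains open whether fluoro or methoxy on the same aromatic carbon would stay near compound 3 or reach the limit like compound 4.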